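A few compounds are considered here, and "the series" means these few. Any claim that something is new, unique, unknown or untested is made for them only; others in the source may bear on it.

Compound 1 `O[C@H](c1ccccn1)[C@]1(c2cccc(OC(F)(F)F)c2)C[C@@H](O)C1`: 117 mL/min/kg
Compound 2 `O[C@]1(c2ccccn2)CC[C@@H](c2ccc(C(F)(F)F)cc2)C1`: 383 mL/min/kg
Compound 3 `O[C@H](c1ccccn1)C1(c2cccc(OC(F)(F)F)c2)CCC1`: 2220 mL/min/kg

In an ADME assay on liver for metabolic stability, with Liver microsome (Homo sapiens) as the target, read by LC-MS, using microsomes, with a stated time of 5 h (on this read-out lower numbers stand for slow clearance and higher numbers for fast clearance), compound 1 gives 117 mL/min/kg, the lowest of the three numbers. Compound 2 reads 383 mL/min/kg and compound 3 reads 2220 mL/min/kg, both clearly higher.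

Compound 4 `O[C@H](c1ccccn1)[C@]1(c2cccc(C(F)(F)F)c2)C[C@@H](O)C1` has not yet been measured. It keeps the core of compound 1 and changes one group, with trifluoromethyl in place of trifluoromethoxy on an aromatic carbon.

For the measured compounds named here, no measured pair isolates this swap. Going by the values given here, the only measured step, a 19-fold higher number from compound 1 to compound 3 (1.28 log units; beyond the scatter), is large, but it comes from a different change: hydrogen in place of hydroxy on a saturated ring carbon. Compound 4 keeps that hydroxy, so this large step offers no reason to expect a similar jump. Compound 2 does carry a trifluoromethyl group, but its core differs too, so its 383 mL/min/kg cannot be credited to that group alone.

With so little direct evidence, the expected result stays close to compound 1, with no shift beyond the scatter. The estimated change is a 1.2-fold lower number from compound 1 to compound 4 (0.07 log units; within the scatter). For compound 4 the estimated clearance is 100 mL/min/kg, with an expected range from 45 mL/min/kg to 230 mL/min/kg.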

Compound 4, clearance: 50 mL/min/kg
Compound 4: the middle estimate sits 2.0-fold (0.30 log units) above what was measured; low and high end bracket the measured number.
By their numbers in this assay, from the lowest: compound 4; then compound 1; then compound 2; then compound 3.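

In this assay, for the compounds shown here, this is the first time a single change has been read at this aromatic carbon, and trifluoromethyl in place of trifluoromethoxy gives a 2.3-fold lower number from compound 1 to compound 4 (0.37 log units; beyond the scatter). The earlier compounds shown here showed only that removing the hydroxy on the saturated ring carbon matters, with a 19-fold higher number from compound 1 to compound 3 (1.28 log units; beyond the scatter); this new step shows that the group on the aromatic ring also moves the number beyond the usual scatter, though by a modest step rather than a large one. Nothing available here explains why clearance falls with this swap, so the step stands as an observation and the loss of the oxygen atom cannot be singled out as its source.

Going by these compounds, it remains open whether the same swap would give a similar step on the core of compound 3, which lacks the hydroxy, so the two changes cannot yet be said to add up or to act independently. On these data alone, it is also open how other small groups at this aromatic carbon, such as a chlorine atom, a methyl group or a nitrile, would compare with trifluoromethyl.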